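Aryl amide variation on the shared core

The source may hold more compounds than are shown below. What is called first, only, known or untested is meant among the compounds shown, and "the series" means these compounds.

Measured so far:
compound 1 `Cc1ccc(C(=O)NCN2CCC(c3cccc[n+]3[O-])CC2)cc1C` — 38 nM
compound 2 `COc1cc(C(=O)NCN2CCC(c3cccc[n+]3[O-])CC2)ccc1Cl` — 159 nM

In a functional assay on HEK293 cells for agonist activity at D(4) dopamine receptor (Homo sapiens), read by FLIPR (a higher number here means that more compound is needed for the effect, a lower number that less compound is needed), compound 1 holds the lowest of the two numbers. Compound 2 stands higher, and the gap between the two values lies beyond the usual scatter, so compound 1 is the more potent of the pair. Among the measured compounds shown here, the two measured compounds differ in more than one place, so no single step between measured compounds is available as a guide.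

Compound 3 `O=C(NCN1CCC(c2cccc[n+]2[O-])CC1)c1ccc(F)c(Cl)c1` has not yet been measured in this assay. It differs from compound 1 in one place: 3-chloro-4-fluorophenyl in place of 3,4-dimethylphenyl on a carbonyl carbon. Both groups match in what is counted, so the change is a swap of substituents on the same ring at the same position of the shared core.

For the measured compounds named here, with no measured step to lean on, the only pointer is that compound 2, which also carries a chlorine on its aryl group, gives 159 nM in this assay, well above compound 1. A modest upward step is therefore expected, estimated as a 1.8-fold higher number from compound 1 to compound 3 (0.27 log units; within the scatter) in this assay, meaning more compound needed than for compound 1. For compound 3 the estimate in this assay is 70 nM, with an expected range from 25 nM to 200 nM.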

Compound 3, half-maximal effective concentration: 63 nM
For compound 3 the middle estimate is 1.1-fold (0.05 log units) above the measured one, within the range that was stated.
By their numbers in this assay, from the lowest: compounds 1 and 3 (each within the scatter of the next); then compound 2.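

In this assay, among the compounds shown here, a 1.7-fold higher number from compound 1 to compound 3 (0.22 log units; within the scatter) is the first single-place reading for the aryl group on the carbonyl carbon. The two groups match in heavy atoms, ring, hydrogen-bond donors and acceptors, and net charge, and they differ in ring substituents: with 3-chloro-4-fluorophenyl in place of 3,4-dimethylphenyl, the two numbers cannot be told apart, so this position of the shared core accepts both substitution patterns within the scatter of the assay. No measured property of either group accompanies this step, so the result stands as a bare observation.

As far as these compounds go, it remains open whether this tolerance extends to unsubstituted phenyl, to a ring carrying a single chlorine or a single fluorine, or to a ring bearing an amine or a carboxylic acid at this place. Also open is how a longer chain between the carbonyl carbon and the aryl group would read in this assay, since every compound shown keeps the aryl group directly on that carbon.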